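Extending the Sulfonyl Chain with an Aminomethyl Group

The source may hold more compounds than are shown below. What is called first, only, known or untested is meant among the compounds shown, and "the series" means these compounds.

Of the compounds shown here, three built on a shared core have been tested in an ADME assay on microsomes from liver (Rattus norvegicus) for metabolic stability, with a stated time of 10 min; on this read-out higher numbers stand for a more stable compound and lower numbers for a less stable compound. Compound 1 `O=C(NS(=O)(=O)c1ccccc1)c1ccc(Nc2nc(NC3(c4ccc(Cl)cc4)CC3)nc(OCC(F)(F)F)n2)cc1` gives 100%. Compound 2 `Cc1ccccc1S(=O)(=O)NC(=O)c1ccc(Nc2nc(NC3(c4ccc(Cl)cc4)CC3)nc(OCC(F)(F)F)n2)cc1` gives 100%, and no change at the digits printed from compound 1 to compound 2 (within the scatter). Compound 3 `CS(=O)(=O)NC(=O)c1ccc(Nc2nc(NC3(c4ccc(Cl)cc4)CC3)nc(OCC(F)(F)F)n2)cc1` gives 85%, which is the lowest of the three numbers, with both other compounds standing beyond the scatter above it.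

Compound 4 `NCCS(=O)(=O)NC(=O)c1ccc(Nc2nc(NC3(c4ccc(Cl)cc4)CC3)nc(OCC(F)(F)F)n2)cc1` has not yet been measured. It differs from compound 3 in one place: aminomethyl in place of hydrogen on a saturated chain carbon bound to a sulfonyl sulfur. Going by the values given here, no measured step matches this change directly. The two steps that reach compound 3 both exchanged the group on the sulfonyl sulfur, putting a methyl where a ring had been, and each lowered the number by a modest amount: a number 15 percentage points lower from compound 1 to compound 3 (beyond the scatter) and a number 15 percentage points lower from compound 2 to compound 3 (beyond the scatter). Among the compounds with values here, the new step instead builds outward from that methyl, so the earlier steps give only a loose guide. A step of at most modest size is expected, more likely downward than upward, with a small fall or no change beyond the scatter both plausible.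

Compound 4 is therefore expected to give 80%, within a range from 55% to 100%, which would mean an expected step of a number 5 percentage points lower from compound 3 to compound 4 (within the scatter).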

Compound 4, percent of the compound remaining: 100%
Estimate against measurement, compound 4: 20 percentage points below, within the range that was stated.
By their numbers in this assay, from the lowest: compound 3; then compounds 1, 2 and 4 (each within the scatter of the next).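

In this assay, the methyl on the sulfonyl sulfur proves open to change: aminomethyl in place of hydrogen on that saturated chain carbon gives a number 15 percentage points higher from compound 3 to compound 4 (beyond the scatter), a move opposite in direction to the two steps that replaced a ring with methyl. A ring on the sulfonyl sulfur is also not required to keep the number where the ring-bearing compounds stand, as 2-aminoethyl, which has no ring, in place of 2-methylphenyl gives no change at the digits printed from compound 2 to compound 4 (within the scatter), and in place of phenyl gives no change at the digits printed from compound 1 to compound 4 (within the scatter). No measurement shown here explains this result.

The compounds shown leave open whether the amine or the longer chain carries the step, a question that a plain ethyl group on the sulfonyl sulfur could help to separate. They also leave open how a 3-aminopropyl, 2-hydroxyethyl or 2-carboxyethyl group in the same place would read in this assay.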